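The source may hold more compounds than are shown below. What is called first, only, known or untested is meant among the compounds shown, and "the series" means these compounds.

Compound 3, `COc1cccc(OC)c1OCCNCCOc1ccccc1OCc1cccc([N+](=O)[O-])c1`, gives 8.74 in a functional assay on spleen for antagonist activity at Alpha-1B adrenergic receptor (Rattus norvegicus) (on this read-out lower numbers stand for lower potency and higher numbers for higher potency (the scale is a negative logarithm)), the highest of the three numbers measured. Compound 1, `COc1cccc(OC)c1OCCNCCOc1ccccc1OCc1ccccc1`, gives 8.3 in this assay, and compound 2, `COc1cccc(OC)c1OCCNCCOc1ccccc1OCc1ccccc1C`, gives 7.67. The step of a number 0.44 log units higher from compound 1 to compound 3 (beyond the scatter) shows the gain that a nitro group brings when it replaces hydrogen on the aromatic carbon; the step of a number 0.63 log units lower from compound 1 to compound 2 (beyond the scatter) shows the loss that a methyl group brings at its own aromatic carbon; and the step of a number 1.07 log units higher from compound 2 to compound 3 (beyond the scatter) combines both. Compound 4, `COc1cccc(OC)c1OCCNCCOc1ccccc1OCc1ccc([N+](=O)[O-])cc1`, keeps every atom of compound 3 and differs only in 4-nitrophenyl in place of 3-nitrophenyl on a saturated chain carbon bound to an oxygen on an aromatic ring. Among the measured compounds shown here, none of the measured steps moves a nitro group from one aromatic carbon to another, so the data give no direct guide to this change. For the measured compounds named here, the nitro group is retained, and the gain in the step from compound 1 to compound 3 is the only comparison that speaks for it. A step within the scatter is therefore expected, a number 0.14 log units lower from compound 3 to compound 4 (within the scatter), and compound 4 is estimated at 8.6, between 8 and 9.1.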

Compound 4, negative logarithm of the antagonist equilibrium constant: 9.02
Beside the measured number, compound 4's estimate is 0.42 log units below it; the range from low to high includes it.
By their numbers in this assay, from the lowest: compound 2; then compound 1; then compounds 3 and 4 (each within the scatter of the next).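

In this assay the step for moving the nitro group, a number 0.28 log units higher from compound 3 to compound 4 (within the scatter), leaves 3-nitrophenyl and 4-nitrophenyl on this saturated chain carbon indistinguishable, so the two placements of the nitro group cannot be told apart here. The gain from nitro in place of hydrogen is therefore not confined to the placement in compound 3, since it also appears as a number 0.72 log units higher from compound 1 to compound 4 (beyond the scatter) and the methyl compound stays well apart with a number 1.35 log units higher from compound 2 to compound 4 (beyond the scatter) in the same read-out. Nothing available here explains the size of any of these steps.

As far as these compounds go, what a nitrile, a carboxylic acid or an amine would give in place of the nitro group remains open, as does 2-nitrophenyl on the same carbon. From the compounds shown here alone, it is also open whether these steps would hold with a longer chain in the shared core.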